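Notes: moving the methoxy from compound 2 to compound 4

This account rests on a few compounds, and the source may have more. Where it says the series, first, only, none or still open, it means among the compounds named here.

- Compound 1 `COC(=O)N1N=C(c2ccccc2)CC1c1cc(OC)c(OC)c(OC)c1` gives 3950 nM
- Compound 2 `COC(=O)N1N=C(c2cccc(OC)c2)CC1c1cc(OC)c(OC)c(OC)c1` gives 1870 nM
- Compound 3 `COc1cccc(C2=NN(C(=O)OCc3ccccc3)C(c3cc(OC)c(OC)c(OC)c3)C2)c1` gives > 10000 nM, which is a limit and not a number

In a functional assay on HepG2 cells (Homo sapiens) for antiproliferative activity, read by MTT assay, with a stated time of 48 h (on this read-out higher numbers stand for weaker inhibition of growth and lower numbers for stronger inhibition of growth), compound 2 has the lower of the two actual numbers, and compound 1 is its nearest neighbour. Compound 4 `COC(=O)N1N=C(c2ccc(OC)cc2)CC1c1cc(OC)c(OC)c(OC)c1` differs from compound 2 as 4-methoxyphenyl in place of 3-methoxyphenyl on a carbon with a double bond to nitrogen, with 4-methoxyphenyl in place of 3-methoxyphenyl on a carbon with a double bond to nitrogen. The closest measured change is the gain of the methoxy group, a 2.1-fold lower number from compound 1 to compound 2 (0.32 log units; beyond the scatter), a modest step. Within the data shown here, no measured pair moves that group, so this step gives only a rough scale. The other step, an at least 5.3-fold higher number from compound 2 to compound 3 (0.72 log units; beyond the scatter), leaves the 3-methoxyphenyl in place and does not bear on this change. No firm direction can be expected, and a step no larger than modest is likely. The expected step is a 1.2-fold higher number from compound 2 to compound 4 (0.07 log units; within the scatter). For compound 4 the estimate is 2200 nM, with an expected range of 700 nM to 7000 nM.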

Compound 4, concentration for 50% growth inhibition: 1710 nM
Compound 4: middle estimate off by 1.3-fold (0.11 log units), on the high side, within the range that was stated.
By their numbers in this assay, from the lowest: compounds 4 and 2 (each within the scatter of the next); then compound 1. At a limit, above all of these: compound 3.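

In this assay compound 2 and compound 4 stand level, a 1.1-fold lower number from compound 2 to compound 4 (0.04 log units; within the scatter), so on this carbon with a double bond to nitrogen the 3-methoxyphenyl and the 4-methoxyphenyl cannot be told apart. The step from the plain phenyl therefore appears with either methoxyphenyl: a 2.3-fold lower number from compound 1 to compound 4 (0.36 log units; beyond the scatter), which stands alongside the earlier 2.1-fold lower number from compound 1 to compound 2 (0.32 log units; beyond the scatter). The numbers show this equivalence for these compounds only, and nothing given here accounts for either step.

Still open, going by these compounds, is whether these steps are specific to the methoxy group, or whether a hydroxyl, a chlorine or a dimethylamino group on the same aromatic ring would give a similar number. Also open, on these data alone, is how a phenyl ring carrying both a 3-methoxy and a 4-methoxy group would compare.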